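A few compounds are considered here, and "the series" means these few. Any claim that something is new, unique, unknown or untested is made for them only; others in the source may bear on it.

Measured so far in an ADME assay on NIH3T3 cells (Mus musculus) for cytotoxicity, read by MTT assay, with a stated time of 48 h (a lower number here means that less compound is tolerated, a higher number that more compound is tolerated), are three compounds:

- compound 1 `COc1ccc(C(C)=O)cc1S(N)(=O)=O` gives > 2700000 nM as a limit
- compound 2 `COc1ccc(C(C)=O)cc1S(=O)(=O)Nc1c(N)nc(SC)[nH]c1=O` gives > 1600000 nM as a limit
- compound 3 `COc1ccc(C(=O)/C=C/c2ccc(Cl)cc2)cc1S(N)(=O)=O` gives 4100 nM as a number

Going by the values given here, compound 3 at 4100 nM holds the only actual number in the set. Among the compounds with values here, compound 1 and compound 2 report limits only, and no measured step between compounds is available.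

The next compound is compound 4 `COc1ccc(/C=C/C(=O)c2ccc(OC)c(S(N)(=O)=O)c2)cc1`, which differs from compound 3 at one place: methoxy in place of chloro on an aromatic carbon. In words, this is methoxy in place of chloro on an aromatic carbon, para to a large group. The same difference reads 4-chlorophenyl to 4-methoxyphenyl.

Within the data shown here, with no measured step as a guide, the expectation rests only on this single replacement and on compound 3 at 4100 nM as the starting point. A small move in this assay is expected, towards somewhat more compound being tolerated, and it may stay within the usual scatter. The estimated change, a 1.5-fold higher number from compound 3 to compound 4 (0.17 log units; within the scatter), is modest on that reading. Compound 4 is expected to return a number and not a limit. Expected for compound 4 is 6000 nM with a range from 1800 nM to 25000 nM by this estimate.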

Compound 4, concentration lethal to 50% of the cells: 96000 nM
The estimate for compound 4 lay 16-fold (1.20 log units) below the measured number; the whole stated range lies below it.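

In this assay the series gains its first readable step, a 23-fold higher number from compound 3 to compound 4 (1.37 log units; beyond the scatter), with methoxy in place of chloro on an aromatic carbon para to a large group. Going by these compounds alone, this position is therefore not silent in this assay: a single replacement that adds only the small methoxy group for chloro moves the number well beyond the scatter, and compound 4 at 96000 nM still gives a number and not a limit, so the change can be sized exactly, which the earlier compounds, with only one number among them, could not offer. Nothing measured here explains the size of this step.

With only chloro and methoxy at this carbon, the compounds shown leave open whether the step follows the entry of methoxy or the departure of chloro, and a hydroxy group, a dimethylamino group or a longer alkoxy chain at the same place would help to separate the two. Also open, from the compounds shown here alone, is whether the same replacement gives a step of similar size on any other compound of the series.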